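Triazole Substituent Exchange on a Chromene Ester Core

A few compounds are considered here, and "the series" means these few. Any claim that something is new, unique, unknown or untested is made for them only; others in the source may bear on it.

Measured compounds:
compound 1 `CCOC(=O)C1=Cc2ccccc2OC1(OCc1cn(-c2ccc(F)cc2)nn1)C(F)(F)F` — 8400 nM
compound 2 `O=C(O)C1=Cc2ccccc2OC1(OCc1cc(-c2ccc(F)cc2)no1)C(F)(F)F` — > 150000 nM
compound 3 `CCOC(=O)C1=Cc2ccccc2OC1(OCc1cc(-c2ccc(OC)cc2)no1)C(F)(F)F` — > 150000 nM

Among the compounds with values here, in a functional assay on HeLa cells (Homo sapiens) for inhibition, read by MTT assay, with a stated time of 24 h (a lower number here means a stronger inhibitor, a higher number a weaker inhibitor), compound 1 gives 8400 nM, the only numerical value among the three measured compounds. Compound 2 gives > 150000 nM in this assay, which is a limit of the assay rather than a number. Compound 3 likewise gives > 150000 nM in this assay, again a limit. Thus compound 1 stands apart as the one compound with a measurable reading, while the other two sit at the limit of > 150000 nM in this assay, at which 2 of the 3 values shown sit.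

Compound 4 `CCOC(=O)C1=Cc2ccccc2OC1(OCc1cn(CC(=O)Nc2ccccc2Br)nn1)C(F)(F)F` has not yet been measured in this assay. It differs from compound 1 in one place: ((2-bromophenyl)carbamoyl)methyl in place of 4-fluorophenyl on an aromatic nitrogen. Within the data shown here, no pair of measured compounds that differ in a single place is available, so the size of this step cannot be read from the data; a step of moderate size in either direction would not be surprising, with a weakening somewhat more plausible than a strengthening.

Compound 4 is therefore expected to give about 15000 nM in this assay, within 4000 nM to 60000 nM. This estimate means an expected step of a 1.8-fold higher number from compound 1 to compound 4 (0.25 log units; within the scatter).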

Compound 4, half-maximal inhibitory concentration: > 150000 nM
Compound 4: a limit, no number; the forecaster's own chance of this, stated with the estimate: 15%; middle value at least 10-fold (1.00 log units) from the limit.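

In this assay compound 4 gives > 150000 nM, which is a limit of the assay and not a number. Within the data shown here, this is the first comparison in the set between compounds that differ in one place: on an aromatic nitrogen, ((2-bromophenyl)carbamoyl)methyl in place of 4-fluorophenyl brings an at least 17-fold higher number from compound 1 to compound 4 (1.25 log units; beyond the scatter). The position is thus not indifferent to what it carries, since this exchange takes the compound from a measurable reading to the limit shared by the other compounds: the limit of > 150000 nM in this assay, at which 3 of the 4 values shown sit.

On these data alone, the true size of the step stays unknown, and the change alters the group in several ways at once, so the part of it that matters cannot be told apart. As far as these compounds go, whether a plain phenyl, a benzyl group or a shorter carbamoylmethyl chain on this nitrogen would keep a measurable reading remains open.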